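The source may report more compounds than this note shows. Statements on the series, on what has been measured and on what is new or still open speak of the compounds shown alone.

Two compounds share one core and differ only in the group on a saturated chain carbon bound to an aromatic nitrogen. Compound 1 `Cc1cc(C)c(Oc2cc(Nc3ccc(C#N)cc3)ncc2C(=O)NCc2cn(Cc3ccccc3[N+](=O)[O-])nn2)c(C)c1` carries 2-nitrophenyl there; in an ADME assay on MT4 cells (Homo sapiens) for cytotoxicity, read by MTT assay, with a stated time of 5 days (on this read-out lower numbers stand for higher toxicity in this test and higher numbers for lower toxicity in this test), compound 1 gives only a limit, > 212000 nM. Among the measured compounds shown here, compound 2 `Cc1cc(C)c(Oc2cc(Nc3ccc(C#N)cc3)ncc2C(=O)NCc2cn(CCCO)nn2)c(C)c1` carries 2-hydroxyethyl instead, and in this assay compound 2 gives 25200 nM, the only number among the two values shown. For the measured compounds named here, the step of an at least 8.4-fold lower number from compound 1 to compound 2 (0.92 log units; beyond the scatter) is the single measured comparison, and its size rests on (the limit of > 212000 nM in this assay, at which 1 of the 2 values shown sits). Compound 3 `Cc1cc(C)c(Oc2cc(Nc3ccc(C#N)cc3)ncc2C(=O)NCc2cn(CC(=O)N3CCCC3)nn2)c(C)c1` is not yet measured; it differs from compound 2 by (pyrrolidin-1-yl)carbonyl in place of 2-hydroxyethyl on a saturated chain carbon bound to an aromatic nitrogen. The measured step went beyond the scatter yet started from a limit, so it is only a loose guide; the entering (pyrrolidin-1-yl)carbonyl is expected to move the number upward, modestly, by a 1.6-fold higher number from compound 2 to compound 3 (0.20 log units; within the scatter). Compound 3 is therefore estimated at 40000 nM in this assay, between 12000 nM and 150000 nM.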

Compound 3, half-maximal cytotoxic concentration: 58100 nM
The estimate for compound 3 lay 1.5-fold (0.16 log units) below the measured number, within the range that was stated.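

In this assay, (pyrrolidin-1-yl)carbonyl in place of 2-hydroxyethyl gives a 2.3-fold higher number from compound 2 to compound 3 (0.36 log units; beyond the scatter), so this position now yields two true numbers that can be told apart, and here the higher number stands for lower toxicity in this test. This change brings in a five-membered ring and a carbonyl and removes the hydrogen-bond donor. The step of an at least 3.6-fold lower number from compound 1 to compound 3 (0.56 log units; beyond the scatter) gives only a bound, and its size rests on a value that is a limit of the assay, not a number: the limit of > 212000 nM in this assay, at which 1 of the 3 values shown sits.

The three groups shown cannot separate the part played by the ring from that of the carbonyl or the lost hydroxyl. Where an open-chain dimethylamide, an amine or a carboxylic acid in this place would fall also stays open.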